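A few compounds are considered here, and "the series" means these few. Any claim that something is new, unique, unknown or untested is made for them only; others in the source may bear on it.

Measured so far in an ADME assay on L02 cells (Homo sapiens) for cytotoxicity, read by MTT assay, with a stated time of 24 h; a higher number here means a weaker inhibitor, a lower number a stronger inhibitor:
compound 1 `O=C1/C(=C/c2cccnc2)CN(S(=O)(=O)c2ccc(C(F)(F)F)cc2)C/C1=C\c1ccccc1F`: 11300 nM
compound 2 `CC(=O)Nc1ccc(S(=O)(=O)N2C/C(=C\c3cccnc3)C(=O)/C(=C/c3ccccc3F)C2)cc1`: 15600 nM
compound 3 `CC(=O)Nc1ccc(S(=O)(=O)N2C/C(=C\c3ccncc3)C(=O)/C(=C/c3ccccc3F)C2)cc1`: 12300 nM

Compound 2 stands highest of the three numbers shown, but its steps to both other compounds sit within the scatter: a 1.4-fold higher number from compound 1 to compound 2 (0.14 log units; within the scatter) and a 1.3-fold lower number from compound 2 to compound 3 (0.10 log units; within the scatter). Compound 2 is therefore not to be called the weakest inhibitor of the three; the three numbers read as one level.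

Compound 4 `CC(=O)Nc1ccc(S(=O)(=O)N2C/C(=C\c3cccnc3)C(=O)/C(=C/c3ccccc3C(F)(F)F)C2)cc1` differs from compound 2 in one place: trifluoromethyl in place of fluoro on an aromatic carbon. For the measured compounds named here, no measured pair carries this change, so there is no direct reference for it. The two steps that exist, acetamido in place of trifluoromethyl on an aromatic carbon and pyridin-4-yl in place of pyridin-3-yl, each stayed within the scatter, which shows that two separate changes in this series left the number in this assay where it was. Nothing measured speaks to the part of the structure that changes from 2-fluorophenyl to 2-(trifluoromethyl)phenyl. On that basis compound 4 is expected to give no step beyond the scatter in this assay, a 1.1-fold lower number from compound 2 to compound 4 (0.05 log units; within the scatter). The estimate for compound 4 in this assay is 14000 nM, with a range from 6000 nM to 35000 nM.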

Compound 4, half-maximal inhibitory concentration: 15300 nM
For compound 4 the middle estimate is 1.1-fold (0.04 log units) below the measured one, and the stated range covers the measured number.
By their numbers in this assay, from the lowest: compounds 1, 3, 4 and 2 (each within the scatter of the next).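

For the compounds shown here, the 2-fluorophenyl to 2-(trifluoromethyl)phenyl change is the first measured change at this part of the structure, and in this assay it gives a 1.0-fold lower number from compound 2 to compound 4 (0.01 log units; within the scatter). At this aromatic carbon, ortho to a large group, a trifluoromethyl of 4 heavy atoms in place of a fluoro of 1 heavy atom therefore leaves the number at the level of compound 2. Together with the two earlier steps, this means that all three single changes measured in the series stay within the scatter, although no evidence at hand bears on this result or explains it.

Fluoro and trifluoromethyl are the only groups shown on this aromatic carbon, leaving open whether an amine or a carboxylic acid there would also stay at this level in this assay. Also open, as far as these compounds go, is whether the level would hold with a group other than trifluoromethyl or acetamido on the aromatic ring of the sulfonyl group, such as a carboxylic acid.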